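Swapping a fluorophenyl for a trimethylphenyl group

This account rests on a few compounds, and the source may have more. Where it says the series, first, only, none or still open, it means among the compounds named here.

Three compounds sharing one core have numbers in a functional assay on K562 cells (Homo sapiens) for cytotoxicity, read by MTT assay, with a stated time of 48 h; a lower number here means a stronger inhibitor, a higher number a weaker inhibitor. They differ only in the fluorophenyl group they carry. Compound 1 (`O=C(CN[C@H]1CCN(S(=O)(=O)Cc2ccccc2)C1)N1CCN(Cc2ccccc2F)CC1`), with 2-fluorophenyl, gives 12600 nM. Compound 2 (`O=C(CN[C@H]1CCN(S(=O)(=O)Cc2ccccc2)C1)N1CCN(Cc2cccc(F)c2)CC1`), with 3-fluorophenyl, gives 13200 nM. Compound 3 (`O=C(CN[C@H]1CCN(S(=O)(=O)Cc2ccccc2)C1)N1CCN(Cc2ccc(F)cc2)CC1`), with 4-fluorophenyl, gives 14300 nM, a number that cannot be told apart from the other two.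

Compound 4 (`Cc1cc(C)c(CN2CCN(C(=O)CN[C@H]3CCN(S(=O)(=O)Cc4ccccc4)C3)CC2)c(C)c1`) has not yet been measured. It differs from compound 3 in one group: 2,4,6-trimethylphenyl in place of 4-fluorophenyl on a saturated chain carbon bound to an amine nitrogen in a ring. The new group, 2,4,6-trimethylphenyl, replaces 4-fluorophenyl on a saturated chain carbon bound to an amine nitrogen in a ring.

For the measured compounds named here, only the steps among the three fluorophenyl compounds bear on this change: a 1.0-fold higher number from compound 1 to compound 2 (0.02 log units; within the scatter), a 1.1-fold higher number from compound 1 to compound 3 (0.05 log units; within the scatter) and a 1.1-fold higher number from compound 2 to compound 3 (0.03 log units; within the scatter). All three are small, so this group has so far made no measurable difference. None of them, however, tests a trimethylphenyl group, so they are only a weak guide and the range must stay wide.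

The expected step is a 1.2-fold lower number from compound 3 to compound 4 (0.08 log units; within the scatter), which means no expected change beyond the scatter. In this assay, the estimate for compound 4 is 12000 nM, with an expected range of 5500 nM to 26000 nM.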

Compound 4, half-maximal inhibitory concentration: 3300 nM
Beside the measured number, compound 4's estimate is 3.6-fold (0.56 log units) above it; the whole stated range lies above it.
By their numbers in this assay, from the lowest: compound 4; then compounds 1, 2 and 3 (each within the scatter of the next).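

In this assay this place on the molecule now proves able to move the number, although swapping among the three fluorophenyl groups had shown no readable difference. Going to 2,4,6-trimethylphenyl gives a 4.3-fold lower number from compound 3 to compound 4 (0.64 log units; beyond the scatter) and a 4.0-fold lower number from compound 2 to compound 4 (0.60 log units; beyond the scatter) and a 3.8-fold lower number from compound 1 to compound 4 (0.58 log units; beyond the scatter), all three steps modest in size but beyond the scatter, so the result does not depend on which fluorophenyl compound serves as the starting point. No supporting measurement is available to explain this shift, so the reason for it remains unknown.

The change removes fluorine and brings in three methyl groups in a single step, so the compounds shown cannot tell whether the lower number comes from losing the fluorine, from one particular methyl group or from all three together. Plain phenyl, 4-methylphenyl and 2,6-dimethylphenyl would separate these possibilities, while larger groups such as 2,4,6-triethylbenzyl or a methoxy-bearing benzyl would show whether the number can fall further at this place.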